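This account rests on a few compounds, and the source may have more. Where it says the series, first, only, none or still open, it means among the compounds named here.

The study rests on two measured compounds in a functional assay on the whole organism for inhibition, with Rattus norvegicus as the target, at a dose of 10 mg/kg by the oral route (a higher number here means a stronger effect of the compound at the dose given, a lower number a weaker effect), and asks what a third, not yet measured, is likely to give. Compound 1 `Cc1cc([N+](=O)[O-])cc(C(=O)Nc2nn[nH]n2)n1` is the weaker of the pair: in this assay compound 1 gives 6%. Compound 2 `COc1cccc(C(=O)Nc2nn[nH]n2)n1` stands highest of the two numbers: in this assay compound 2 gives 58%, and the gap to compound 1 lies beyond the scatter of the measurement. Compound 1 and compound 2 differ in more than one place. Among the compounds with values here, no single change can be tied to that gap, and no step between measured compounds is available.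

Compound 3 `O=C(Nc1nn[nH]n1)c1cccc(Oc2ccccc2)n1` is the unmeasured compound. It differs from compound 2 in one place: phenyl in place of methyl on an oxygen on an aromatic ring. Within the data shown here, no measured pair shows what such a change does, so the expectation rests on compound 2 alone and carries a wide range. The expected step is a number 13 percentage points lower from compound 2 to compound 3 (beyond the scatter), a small drop that may well lie within the scatter. Compound 3 is therefore estimated at 45%, with a range from 15% to 75%.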

Compound 3, a percentage reported as inhibition, in the whole organism at one dose (the size of the read-out at that dose, not a potency): 0%
For compound 3 the middle estimate is 45 percentage points above the measured one; the whole stated range lies above it.
By their numbers in this assay, from the lowest: compounds 3 and 1 (each within the scatter of the next); then compound 2.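

In this assay, within the data shown here, the change from methoxy to phenoxy is the only single change that can be read, and it gives a number 58 percentage points lower from compound 2 to compound 3 (beyond the scatter), so at this place the effect seen with methyl on the oxygen does not survive the exchange for phenyl. The group that enters has 6 heavy atoms, all carbon, in one six-membered aromatic ring, against the 1 carbon of the group that leaves, while neither group brings hydrogen-bond donors, hydrogen-bond acceptors or a net charge, so the step goes with a larger, ring-bearing group and no difference in those counts. Nothing available here bears on why the effect falls away at this dose.

The compounds shown leave open whether a short chain such as ethoxy or a benzyloxy group on the same aromatic ring would keep any of the effect of compound 2, and what an amine in place of the oxygen would give. As every number comes from a single oral dose, they also leave open how compound 2 and compound 3 would compare at other doses.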